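The source may hold more compounds than are shown below. What is called first, only, known or untested is meant among the compounds shown, and "the series" means these compounds.

Measured so far:
compound 1 `CCOC(=O)c1c(-c2ccc(OC)cc2)oc2ccc(OCCCN3C(=O)C(=O)c4cc(F)ccc43)cc12` — 256000 nM
compound 2 `CCOC(=O)c1c(-c2ccc(F)cc2)oc2ccc(OCCCN3C(=O)C(=O)c4cc(F)ccc43)cc12` — 512000 nM
compound 3 `CCOC(=O)c1c(-c2ccc(OC)cc2)oc2ccc(OCCCCCN3C(=O)C(=O)c4cc(F)ccc43)cc12` — 128000 nM

All three were tested in an ADME assay on Vero cells (Chlorocebus sabaeus) for cytotoxicity, read by MTT assay, with a stated time of 72 h; a lower number here means that less compound is tolerated, a higher number that more compound is tolerated. Compound 2 gives 512000 nM, and compound 1 gives 256000 nM, a value within the scatter of it; compound 3, which gives 128000 nM, lies further away, beyond the scatter, on the lower side. The one step among these compounds that changes a single group is a 2.0-fold higher number from compound 1 to compound 2 (0.30 log units; within the scatter), a swap on the pendant aromatic ring.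

Compound 4 `CCOC(=O)c1c(-c2ccc(F)cc2)oc2ccc(OCCCN3C(=O)C(=O)c4cc(OC)ccc43)cc12` is not yet measured. It differs from compound 2 by methoxy in place of fluoro on an aromatic carbon. This is the same pair of groups as in the step from compound 1 to compound 2, exchanged in the opposite direction and on a different ring. That step stayed within the scatter, so in this assay no step beyond the scatter is expected here either, perhaps a slight move toward lower numbers. Compound 4 is therefore estimated at 300000 nM, with a range from 120000 nM to 650000 nM, which is expected to amount to a 1.7-fold lower number from compound 2 to compound 4 (0.23 log units; within the scatter).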

Compound 4, half-maximal cytotoxic concentration: 128000 nM
Compound 4: the middle estimate sits 2.3-fold (0.37 log units) above what was measured; low and high end bracket the measured number.
By their numbers in this assay, from the lowest: compounds 3, 4, 1 and 2 (each within the scatter of the next, the first and the last beyond it).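

In this assay, putting methoxy in place of fluoro on this six-membered aromatic ring of carbon only, part of a fused system of two rings, gives a 4.0-fold lower number from compound 2 to compound 4 (0.60 log units; beyond the scatter), a modest step but one beyond the scatter. The same two groups exchanged on the pendant aromatic ring gave a 2.0-fold higher number from compound 1 to compound 2 (0.30 log units; within the scatter), so this pair of groups does not read the same at the two places. Nothing measured here bears on what lies behind this step.

Going by these compounds, it remains open whether the step belongs to methoxy in particular or would also appear with an amine or a chlorine atom on this carbon. On these data alone, it is also open whether the same exchange would give a similar step on compound 3, which carries the longer chain.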